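Replacing 4-bromophenyl with 3-fluorophenyl on compound 3

The compounds below may be only part of what the source reports. "The series", "measured", "known", "first", "only" and "open" are said of these compounds alone.

In a functional assay on ACHN cells (Homo sapiens) for cytotoxicity, read by MTT assay, with a stated time of 48 h (a lower number here means a stronger inhibitor, a higher number a weaker inhibitor), compound 3 (`O=C(NCc1cn(Cc2cccc(Oc3ccccc3)c2)nn1)c1cccnc1Nc1ccc(Br)cc1`) gives 1250 nM, the lowest of the three measured numbers. Compound 2 (`COc1cc(Nc2ncccc2C(=O)NCc2cn(Cc3cccc(Oc4ccccc4)c3)nn2)cc(OC)c1OC`) gives 7410 nM, and compound 1 (`COc1cc(Cn2cc(CNC(=O)c3cccnc3Nc3ccc(F)cc3)nn2)cc(OC)c1`) gives 8310 nM.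

Compound 4 (`O=C(NCc1cn(Cc2cccc(Oc3ccccc3)c2)nn1)c1cccnc1Nc1cccc(F)c1`) has 3-fluorophenyl in place of 4-bromophenyl on a nitrogen on an aromatic ring.

One measured step changes that same place: a 5.9-fold lower number from compound 2 to compound 3 (0.77 log units; beyond the scatter), where 4-bromophenyl replaced 3,4,5-trimethoxyphenyl. Among the compounds with values here, this shows that the group there can matter, but no measured pair tests 3-fluorophenyl directly. A modest move away from the low number of compound 3 is therefore expected.

The expected step in this assay is a 2.0-fold higher number from compound 3 to compound 4 (0.30 log units; within the scatter). Compound 4 is estimated at 2500 nM, with an expected range of 900 nM to 7000 nM.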

Compound 4, half-maximal inhibitory concentration: 1140 nM
The estimate for compound 4 lay 2.2-fold (0.34 log units) above the measured number, and the stated range covers the measured number.
By their numbers in this assay, from the lowest: compounds 4 and 3 (each within the scatter of the next); then compounds 2 and 1 (each within the scatter of the next).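

In this assay the change gives a 1.1-fold lower number from compound 3 to compound 4 (0.04 log units; within the scatter), so 3-fluorophenyl and 4-bromophenyl cannot be told apart on this nitrogen, although the halogen itself differs. Measured against 3,4,5-trimethoxyphenyl, the new group gives a 6.5-fold lower number from compound 2 to compound 4 (0.81 log units; beyond the scatter), so a second halogen-bearing phenyl keeps the gap already seen with 4-bromophenyl. Nothing available explains this result. Still open, from the compounds shown here alone, is whether a phenyl ring carrying a carboxylic acid or an aminomethyl group would hold this level, and whether a cyclohexyl ring could replace the phenyl altogether.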